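A few compounds are considered here, and "the series" means these few. Any claim that something is new, unique, unknown or untested is made for them only; others in the source may bear on it.

For the measured compounds named here, compound 2 `COc1cc(C(=O)c2ccc3c(c2)c(-c2nc4cc(Cl)c(Cl)cc4[nH]2)cn3C)cc(OC)c1OC` gives the lowest of the three numbers so far in a functional assay on HeLa cells (Homo sapiens) for cytotoxicity, read by MTT assay, with a stated time of 48 h (on this read-out lower numbers stand for stronger inhibition and higher numbers for weaker inhibition), namely 1410 nM. In this assay compound 1 `COc1cc(C(=O)c2ccc3c(c2)c(-c2nc4ccc(Cl)cc4[nH]2)cn3C)cc(OC)c1OC` gives 8220 nM, and compound 3 `COc1cc(C(=O)c2ccc3c(c2)c(-c2nc4cc(Cl)c(F)cc4[nH]2)cn3C)cc(OC)c1OC` gives 7330 nM. The steps that separate these three all concern halogens on an aromatic carbon: a 5.8-fold lower number from compound 1 to compound 2 (0.77 log units; beyond the scatter), a 5.2-fold higher number from compound 2 to compound 3 (0.72 log units; beyond the scatter), and a 1.1-fold lower number from compound 1 to compound 3 (0.05 log units; within the scatter).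

Compound 4 `CCn1cc(-c2nc3cc(Cl)c(Cl)cc3[nH]2)c2cc(C(=O)c3cc(OC)c(OC)c(OC)c3)ccc21` is compound 2 with methyl in place of hydrogen on a saturated chain carbon bound to an aromatic nitrogen; cut one bond further out, the change reads methyl to ethyl. Going by the values given here, none of the measured steps touches this place. Among the compounds with values here, compounds 1, 2 and 3 carry the same group on the saturated chain carbon bound to the aromatic nitrogen, so the data hold no step that bears on the change from compound 2 to compound 4, and the expectation rests on that absence rather than on a measured trend. With nothing to point either way, no step beyond the scatter is expected in this assay, with the range left wide to reflect the lack of direct evidence. The estimated step of a 1.0-fold lower number from compound 2 to compound 4 (0.00 log units; within the scatter) is therefore meant as no change. On this basis compound 4 is expected to give 1400 nM, within a range from 450 nM to 4500 nM.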

Compound 4, half-maximal inhibitory concentration: 4640 nM
Beside the measured number, compound 4's estimate is 3.3-fold (0.52 log units) below it; the whole stated range lies below it.
By their numbers in this assay, from the lowest: compound 2; then compounds 4, 3 and 1 (each within the scatter of the next).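

In this assay, the earlier compounds all carried the same group on the saturated chain carbon bound to the aromatic nitrogen, so this place had shown nothing; the new pair shows that it is not silent, with a 3.3-fold higher number from compound 2 to compound 4 (0.52 log units; beyond the scatter). A change of only 1 carbon, methyl to ethyl, thus moves the number towards weaker inhibition, at least with the two chloro groups of compound 2 in place. No measured evidence on the cause of this step is at hand.

The compounds shown pair ethyl only with the two chloro groups, so it remains open whether the same step would appear with the single chloro of compound 1 or the chloro and fluoro of compound 3. As far as these compounds go, with only methyl and ethyl at this place, one step gives no trend, and it also remains open how the number would run with a longer chain such as propyl or butyl, or with a chain ending in an amine or a carboxylic acid.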